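This account rests on a few compounds, and the source may have more. Where it says the series, first, only, none or still open, it means among the compounds named here.

Of the compounds shown here, three have so far been measured in an ADME assay on Vero cells (Chlorocebus sabaeus) for cytotoxicity, with a stated time of 72 h, tested at 50 ug/mL; on this read-out lower numbers stand for a weaker effect and higher numbers for a stronger effect at the one concentration tested. Compound 1 `COc1ccccc1N1CCn2c1n[nH]c(=O)c2=O` gives 17% in this assay, compound 2 `N=c1c(=O)[nH]nc2n1CCN2c1ccccc1Cl` gives 2%, and compound 3 `COc1ccc(N2CCn3c2n[nH]c(=O)c3=O)cc1` gives 10%. Compound 3 therefore stands close to both others: its reading lies within the usual scatter of compound 1 and also within the usual scatter of compound 2, so these three numbers cannot be told apart with confidence. The next compound, compound 4 `Cc1ccc(N2CCn3c2n[nH]c(=O)c3=O)cc1`, differs from compound 3 in one place: methyl in place of methoxy on an aromatic carbon. Since the three measured compounds already sit together at the low end, the step from compound 3 to compound 4 is expected to be small, no change at the digits printed from compound 3 to compound 4 (within the scatter), with no change beyond the scatter. Compound 4 is accordingly estimated at 10%, ranging from 0% to 25%.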

Compound 4, a percentage reported as inhibition, at one concentration (the size of the read-out at that concentration, not a potency): 0%
Compound 4: middle estimate off by 10 percentage points, on the high side; low and high end bracket the measured number.
By their numbers in this assay, from the lowest: compounds 4, 2, 3 and 1 (each within the scatter of the next, the first and the last beyond it).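

Placing methyl in place of methoxy on this aromatic carbon, para to a large group, gives a number 10 percentage points lower from compound 3 to compound 4 (within the scatter) in this assay. For this one position and this one change, the step therefore cannot be told from repeat-to-repeat variation, even though one oxygen atom has left the compound. Nothing available explains the step.

On these data alone, whether an amine or a carboxylic acid on this same carbon would give a step beyond the scatter remains open. So does whether a longer chain there would.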